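The source may hold more compounds than are shown below. What is called first, only, known or untested is meant among the compounds shown, and "the series" means these compounds.

In an in vitro functional assay on HEK285-7 cells for antagonist activity at prostaglandin D2 receptor 2 (Homo sapiens), read by BRET and beta-arrestin recruitment (on this read-out higher numbers stand for larger maximal responses and lower numbers for smaller maximal responses), three compounds have been measured so far. Compound 1 `O=C(O)Cc1sc(C(c2ccc(F)cc2)c2ccc(F)cc2)nc1-c1ccc(Cl)cc1` gives 80%. Compound 2 `N#Cc1ccc(-c2nc(C(c3ccc(F)cc3)c3ccc(F)cc3)sc2CC(=O)O)cc1` gives 30%, a change of a number 50 percentage points lower from compound 1 to compound 2 (beyond the scatter). Compound 3 `NS(=O)(=O)c1cccc(-c2nc(C(c3ccc(F)cc3)c3ccc(F)cc3)sc2CC(=O)O)c1` gives 55%, which places it second highest of the three; the step of a number 25 percentage points lower from compound 1 to compound 3 (beyond the scatter) separates it from compound 1, and the step of a number 25 percentage points higher from compound 2 to compound 3 (beyond the scatter) separates it from compound 2.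

The next compound, compound 4 `O=C(O)Cc1sc(C(c2ccc(F)cc2)c2ccc(F)cc2)nc1-c1cc(F)cc(F)c1`, has not yet been measured in this assay. It differs from compound 3 in one place: 3,5-difluorophenyl in place of 3-sulfamoylphenyl on an aromatic carbon. Among the measured compounds shown here, no measured step covers this exchange directly. For the measured compounds named here, the steps that bear on the position are those between compounds 1, 2 and 3, all of which change the group on this aromatic carbon, and all of them were beyond the scatter. Of those, compound 1, which carries a chloro group on its phenyl ring, shows the highest maximal response, while compound 2 shows the lowest.

Since compound 4 carries two fluoro groups and no sulfamoyl group, the expectation is a step of a number 15 percentage points higher from compound 3 to compound 4 (beyond the scatter), with compound 4 estimated at 70%, within a range of 45% to 90%.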

Compound 4, largest response reached (reported as efficacy), in percent of the reference or control that the assay uses: 80%
Estimate against measurement, compound 4: 10 percentage points below; the range from low to high includes it.
By their numbers in this assay, from the lowest: compound 2; then compound 3; then compounds 1 and 4 (each within the scatter of the next).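

In this assay, 3,5-difluorophenyl in place of 3-sulfamoylphenyl gives a number 25 percentage points higher from compound 3 to compound 4 (beyond the scatter), and in place of 4-cyanophenyl it gives a number 50 percentage points higher from compound 2 to compound 4 (beyond the scatter). In place of 4-chlorophenyl it gives no change at the digits printed from compound 1 to compound 4 (within the scatter), so a second halogen-bearing phenyl group now stands level with the 4-chlorophenyl group, while the phenyl groups bearing nitrile and sulfamoyl both read lower, and none of the four compounds goes against this division. Nothing given here accounts for these differences in maximal response.

These exchanges alter both the substituent and where it sits on the phenyl ring, so the compounds shown do not separate the effect of the group from that of its place. They also leave open how this read-out would respond to a single fluoro group, a methoxy group, an amine or a carboxylic acid on this phenyl ring, and whether a phenyl group without any substituent would stand with compounds 1 and 4 or with the lower pair.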